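The compounds below may be only part of what the source reports. "The series", "measured", "known", "first", "only" and "open" are said of these compounds alone.

Measured in a functional assay on HeLa cells (Homo sapiens) for cytotoxicity, read by MTT assay, with a stated time of 48 h; a higher number here means a weaker inhibitor, a lower number a stronger inhibitor:
- compound 1 `COc1cc([C@@H]2C[C@]2(CO)C(=O)Nc2ccccc2Cl)cc(OC)c1OC`: 8100 nM
- compound 2 `CCOC(=O)[C@]1(C(=O)Nc2ccccc2)C[C@H]1c1cc(OC)c(OC)c(OC)c1`: > 100000 nM (a limit of the assay)
- compound 3 `COc1cc([C@H]2C[C@@]2(CO)C(=O)Nc2ccccc2)cc(OC)c1OC`: > 100000 nM (a limit of the assay)

Compound 3 gives > 100000 nM, which is a limit and not a number. It shares that limit with one other compound: the limit of > 100000 nM in this assay, at which 2 of the 3 values shown sit. Among the measured compounds shown here, compound 1 gives 8100 nM, the only true number in the set.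

Compound 4 `COc1cc([C@@H]2C[C@]2(CO)C(=O)Nc2ccccc2)cc(OC)c1OC` has not yet been measured. It is the mirror image of compound 3, with the same atoms and bonds: the two compounds have the same atoms and bonds and differ only in configuration as drawn: 2 of 2 stereo elements differ (all stereocentres are inverted: mirror images); a stereocentre at a saturated ring carbon is drawn R in compound 3 and S in compound 4; a stereocentre at a saturated ring carbon is drawn R in compound 3 and S in compound 4. For the measured compounds named here, no measured pair here shows what such an inversion does in this assay. The size of any step cannot be read from compound 3, whose value is only a limit. A move towards stronger inhibition is expected, though compound 4 may well remain at the limit too. The estimate means an at least 2.5-fold lower number from compound 3 to compound 4 (0.39 log units; beyond the scatter), an expected step of uncertain size. Compound 4 is estimated at 40000 nM, with an expected range from 8000 nM to 100000 nM.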

Compound 4, half-maximal inhibitory concentration: 32000 nM
Compound 4: middle estimate off by 1.3-fold (0.10 log units), on the high side; low and high end bracket the measured number.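

In this assay, among the compounds shown here, inverting both stereocentres gives an at least 3.1-fold lower number from compound 3 to compound 4 (0.49 log units; beyond the scatter), a step that starts from a limit, and configuration as drawn is the only change: the fact that compounds 3 and 4 differ only in the configuration as drawn. Hydroxymethyl in place of ethoxycarbonyl on a saturated ring carbon gives an at least 3.1-fold lower number from compound 2 to compound 4 (0.49 log units; beyond the scatter), and this step also starts from a limit: the limit of > 100000 nM in this assay, at which 2 of the 4 values shown sit. Hydrogen in place of chloro on an aromatic carbon gives a 4.0-fold higher number from compound 1 to compound 4 (0.60 log units; beyond the scatter), the only one of these steps measured between two true numbers, so chloro goes with the lower number in this pair.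

On these data alone, the true sizes of the two steps that start from a limit remain open. As far as these compounds go, it is also open whether bromo or methyl in place of chloro, or an amine in place of the hydroxyl of hydroxymethyl, would change the number further.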